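Trading a chlorinated ring for a methylsulfanyl ring

The source may hold more compounds than are shown below. What is called first, only, known or untested is meant among the compounds shown, and "the series" means these compounds.

Measured compounds so far:
- compound 1, `COc1cc(O)c(C(=O)/C=C/c2ccc(F)cc2)c(OC)c1`: 30%
- compound 2, `COc1cc(OC)c(C(=O)/C=C/c2ccc(Cl)cc2)c(OC)c1`: 1.5%
- compound 3, `COc1cccc(/C=C/C(=O)c2c(O)cc(OC)cc2OC)c1`: 34%

All three were tested in a functional assay on Caco-2 cells (Homo sapiens), read by fluorescence and BrdU incorporation, with a stated time of 48 h, tested at 25 uM; a lower number here means a stronger effect, a higher number a weaker effect of the compound at the concentration tested. Among them, compound 2 stands lowest, which here means the strongest effect at the concentration tested. The gap from compound 2 to compound 1 and the gap from compound 2 to compound 3 are both wider than the usual scatter of such measurements, so compound 2 can fairly be called the strongest of the three.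

The next compound to be measured is compound 4, `COc1cc(OC)c(C(=O)/C=C/c2ccccc2SC)c(OC)c1`. It keeps the shared core of compound 2 and differs from it in one place: 2-(methylsulfanyl)phenyl in place of 4-chlorophenyl on a double-bonded chain carbon bound to a double-bonded chain carbon.

Within the data shown here, no pair of measured compounds shows this kind of exchange, so there is nothing to copy from. Among the measured compounds shown here, compounds 1 and 3 show only that a different core can sit far above compound 2, not what a change on the ring at the end of the chain does. The expectation for compound 4 is therefore a modest rise in this assay, a step of a number 8.5 percentage points higher from compound 2 to compound 4 (within the scatter) from compound 2, but with wide uncertainty. Compound 4 is estimated at 10%, within a range from 1% to 40%.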

Compound 4, a percentage reported as activity, at one concentration (the size of the read-out at that concentration, not a potency): 2.2%
For compound 4 the middle estimate is 7.8 percentage points above the measured one, and the stated range covers the measured number.
By their numbers in this assay, from the lowest: compounds 2 and 4 (each within the scatter of the next); then compounds 1 and 3 (each within the scatter of the next).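

In this assay, putting 2-(methylsulfanyl)phenyl in place of 4-chlorophenyl on a double-bonded chain carbon bound to a double-bonded chain carbon gives a number 0.7 percentage points higher from compound 2 to compound 4 (within the scatter), so this read-out does not tell the two groups apart. Among these compounds, this is the first direct one-place comparison in the set, and it shows that the strong effect of compound 2 at the concentration tested survives when the chlorine is lost and a ring with a methylsulfanyl group takes its place, even though the entering group brings one more heavy atom and a hydrogen-bond acceptor. Nothing measured here explains why the two groups read alike.

This single step also changes both the substituent and the number in the group's name at once, so it cannot show which of these matters, if either does. On these data alone, how far this freedom at the end of the chain extends remains open, since a carboxylic acid or an amine on that ring, or an ethylsulfanyl group in place of methylsulfanyl, could behave quite differently.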